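Chain amine in place of the hydroxyl on the flavone side chain

The source may hold more compounds than are shown below. What is called first, only, known or untested is meant among the compounds shown, and "the series" means these compounds.

In a functional assay for inhibition, with Rattus norvegicus as the target, using microsomes (on this read-out higher numbers stand for weaker inhibition and lower numbers for stronger inhibition), compound 3 `O=c1c(OCCO)c(-c2ccc(O)c(O)c2)oc2ccccc12` gives 600 nM, the lowest number of the three measured compounds. Within the data shown here, compound 1 `O=c1cc(-c2ccc(O)c(O)c2)oc2cc(OCCO)ccc12` gives 16400 nM and compound 2 `C[N+](C)(C)CCCOc1ccc2c(=O)cc(-c3ccc(O)c(O)c3)oc2c1` gives 37300 nM; both carry the side chain at a different position of the shared core than compound 3, so no single-point step connects them to compound 3.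

Compound 4 `CN(C)CCCOc1c(-c2ccc(O)c(O)c2)oc2ccccc2c1=O` differs from compound 3 by (dimethylamino)methyl in place of hydroxy on a saturated chain carbon, two bonds along the chain from an oxygen on an aromatic ring.

Among the measured compounds shown here, the only measured step on the same chain is a 2.3-fold higher number from compound 1 to compound 2 (0.36 log units; beyond the scatter), where a charged group of 5 heavy atoms (4 carbon, 1 nitrogen; no ring) replaced one oxygen atom at the same place. The present change is smaller and brings no net charge, but points the same way. A modest rise in the number is therefore expected for compound 4, with a 2.0-fold higher number from compound 3 to compound 4 (0.30 log units; within the scatter) as the expected step.

Compound 4 is estimated at 1200 nM in this assay, with a range from 400 nM to 4000 nM.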

Compound 4, half-maximal inhibitory concentration: 1000 nM
Compound 4: middle estimate off by 1.2-fold (0.08 log units), on the high side, within the range that was stated.
By their numbers in this assay, from the lowest: compounds 3 and 4 (each within the scatter of the next); then compound 1; then compound 2.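

In this assay the change from 2-hydroxyethoxy to 3-(dimethylamino)propoxy gives a 1.7-fold higher number from compound 3 to compound 4 (0.22 log units; within the scatter) and so makes no readable difference on this chain. At this place the chain end accepts (dimethylamino)methyl, with no hydrogen-bond donor and no net charge, in exchange for hydroxy, so the hydroxy is not required for the number seen with compound 3. Among these compounds, this rests on one pair only, and it is the first step that can be read for the side chain at this place on the shared core.

Still open, from the compounds shown here alone, is how a trimethylammonium end, as carried by compound 2, would read at this place, and likewise a carboxylic acid or a longer chain. No measured evidence bears on why the two numbers stay this close.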